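Amino for chloro on the core: outlook for compound 3

This account rests on a few compounds, and the source may have more. Where it says the series, first, only, none or still open, it means among the compounds named here.

Measured so far:
compound 1 `ClCc1ccccc1Cn1cnc2c(Cl)nc(Cl)nc21` — 5490 nM
compound 2 `ClCc1ccc(Cn2cnc3c(Cl)nc(Cl)nc32)cc1` — 5500 nM

In a functional assay on T47D cells (Homo sapiens) for cytotoxicity, read by sulforhodamine B assay, with a stated time of 48 h (on this read-out lower numbers stand for stronger inhibition of growth and higher numbers for weaker inhibition of growth), compound 1 gives 5490 nM and compound 2 gives 5500 nM. The two numbers lie within the scatter of each other, so compound 1 stands level with compound 2 and no order between them can be read. Compound 3 `Nc1nc(Cl)c2ncn(Cc3ccccc3CCl)c2n1` has not been measured. It differs from compound 1 by amino in place of chloro on an aromatic carbon. Within the data shown here, no step between measured compounds bears on this change; the only pair available differs in the placement of the chloromethyl group on the benzyl ring and shows no step beyond the scatter. For compound 3 the change is expected to bring at most a modest step toward weaker inhibition of growth, a 1.3-fold higher number from compound 1 to compound 3 (0.11 log units; within the scatter), with a level result well within reach. Compound 3 is estimated at 7000 nM, in a range from 2500 nM to 20000 nM.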

Compound 3, concentration for total growth inhibition: 83200 nM
Beside the measured number, compound 3's estimate is 12-fold (1.08 log units) below it; the whole stated range lies below it.
By their numbers in this assay, from the lowest: compounds 1 and 2 (each within the scatter of the next); then compound 3.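

In this assay the chloro on the aromatic carbon between two ring nitrogen atoms turns out to count for much: amino in its place gives a 15-fold higher number from compound 1 to compound 3 (1.18 log units; beyond the scatter) and thus a large step toward weaker inhibition of growth. Among these compounds, the only earlier pair varied the placement of the chloromethyl group on the benzyl ring and showed no step beyond the scatter, so this is the first sign that the series responds to a change on the shared core. Nothing at hand accounts for the size of this step.

Open, from the compounds shown here alone, is whether the loss is specific to amino or follows any loss of this chloro, which a methoxy group, a methylamino group or a plain hydrogen at this carbon would help to separate. Also open, going by these compounds, is whether the same exchange gives a step of similar size with the chloromethyl group placed as in compound 2.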